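Chloro to hydroxyethoxy on the benzimidazole of compound 1

The source may hold more compounds than are shown below. What is called first, only, known or untested is meant among the compounds shown, and "the series" means these compounds.

Among the compounds with values here, compound 1 `C[C@@H]1CN(c2sc(C(F)(F)F)nc2-c2nc3cc(Cl)ccc3[nH]2)CCN1C(=O)Cn1cnc2cccnc21` gives 2.8 nM in a functional assay on CHO-K1 cells for antagonist activity at C-X-C chemokine receptor type 3 (Homo sapiens), read by FLIPR, with a stated time of 10 min, in the presence of a further agent that is not named here (on this read-out lower numbers stand for stronger inhibition and higher numbers for weaker inhibition), the lowest of the three numbers measured so far. Compound 3 `C[C@@H]1CN(c2sc(C(F)(F)F)nc2-c2nc3ccc(CO)cc3[nH]2)CCN1C(=O)Cn1cnc2cccnc21` gives 4.6 nM in this assay, and compound 2 `Cc1nc(C)n(CC(=O)N2CCN(c3sc(C(F)(F)F)nc3-c3nc4ccc(C(C)(C)O)c(F)c4[nH]3)C[C@H]2C)n1` gives 9.4 nM. Within the data shown here, the only single-point change measured is a 1.6-fold higher number from compound 1 to compound 3 (0.22 log units; within the scatter), so a polar group in place of chloro on the benzimidazole has so far made no difference beyond the scatter, though compound 3 carries it at a different position. Compound 2 differs from compound 1 in several places and its number is simply higher.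

Compound 4 `C[C@@H]1CN(c2sc(C(F)(F)F)nc2-c2nc3cc(OCCO)ccc3[nH]2)CCN1C(=O)Cn1cnc2cccnc21` is not yet measured. It differs from compound 1 by 2-hydroxyethoxy in place of chloro on an aromatic carbon. The step from compound 1 to compound 3 is the only one that bears on this change, and it stayed within the scatter. Among the measured compounds shown here, a larger group entering at the position of the chloro has no measured precedent here, so some widening of the range is warranted, with a slight lean toward weaker inhibition. For compound 4 the expected step is a 1.8-fold higher number from compound 1 to compound 4 (0.25 log units; within the scatter). Compound 4 is therefore estimated at 5 nM in this assay, in a range from 2 nM to 14 nM.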

Compound 4, half-maximal inhibitory concentration: 2.1 nM
Compound 4: the middle estimate sits 2.4-fold (0.38 log units) above what was measured, within the range that was stated.
By their numbers in this assay, from the lowest: compounds 4, 1 and 3 (each within the scatter of the next, the first and the last beyond it); then compound 2.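

With 2-hydroxyethoxy in place of chloro, a 1.3-fold lower number from compound 1 to compound 4 (0.12 log units; within the scatter) in this assay, so this position accepts a group of 4 heavy atoms in place of a single chlorine with no difference beyond the scatter. Within the data shown here, the earlier step, a 1.6-fold higher number from compound 1 to compound 3 (0.22 log units; within the scatter), put hydroxymethyl at a different place on the benzimidazole, so it said nothing direct about this position; the present pair is the first to change the chloro in its own place, and a hydrogen-bond donor and hydrogen-bond acceptors enter there without moving the number beyond the scatter. Nothing available explains why the number holds across this change.

Still open, from the compounds shown here alone, is how far this acceptance extends: methoxy, a longer chain such as 3-hydroxypropoxy, an amine or a carboxylic acid in this place could each read differently from 2-hydroxyethoxy. Going by these compounds, the 2-hydroxyethoxy group also appears here only on the core of compound 1, so it remains unknown whether the same exchange would stay within the scatter on a compound carrying the other amide substituent of compound 2.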